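The source may report more compounds than this note shows. Statements on the series, on what has been measured and on what is new or still open speak of the compounds shown alone.

Series in a functional assay on DLD-1 cells (Homo sapiens) for cytotoxicity, with a stated time of 48 h; a higher number here means a weaker inhibitor, a lower number a stronger inhibitor:
compound 1 `CC(C)C(=O)Oc1ccc2oc(/C=C/[S+](C)[O-])cc(=O)c2c1` gives 9100 nM
compound 2 `C[S+]([O-])/C=C/c1cc(=O)c2ccccc2o1` gives 8000 nM
compound 3 `CCC(=O)Oc1ccc2oc(/C=C/[S+](C)[O-])cc(=O)c2c1` gives 9000 nM

Compound 3 sits second highest of the three numbers, yet all three lie within the scatter of one another, so no order can be read among them. Compound 4 `C[S+]([O-])/C=C/c1cc(=O)c2cc(F)ccc2o1` differs from compound 3 by fluoro in place of propanoyloxy on an aromatic carbon. Among the measured compounds shown here, the steps that bear on this position are a 1.1-fold higher number from compound 2 to compound 3 (0.05 log units; within the scatter) and a 1.1-fold lower number from compound 1 to compound 2 (0.06 log units; within the scatter). Both lie within the scatter: hydrogen, propanoyloxy and (isopropylcarbonyl)oxy at this aromatic carbon all gave numbers within the scatter of one another. Fluoro at the same place is expected to behave alike, with no step beyond the scatter. The expected step is a 1.1-fold lower number from compound 3 to compound 4 (0.02 log units; within the scatter). Compound 4 is therefore estimated at 8500 nM, with a range from 4000 nM to 18000 nM.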

Compound 4, half-maximal inhibitory concentration: 7000 nM
Compound 4: middle estimate off by 1.2-fold (0.08 log units), on the high side; the range from low to high includes it.
By their numbers in this assay, from the lowest: compounds 4, 2, 3 and 1 (each within the scatter of the next).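

In this assay fluoro at this aromatic carbon stays level with the other groups tried there: a 1.1-fold lower number from compound 2 to compound 4 (0.06 log units; within the scatter) and a 1.3-fold lower number from compound 3 to compound 4 (0.11 log units; within the scatter) and also a 1.3-fold lower number from compound 1 to compound 4 (0.11 log units; within the scatter) all lie within the scatter. Even the exchange of propanoyloxy, with 5 heavy atoms and 2 hydrogen-bond acceptors, for fluoro, with 1 heavy atom and no acceptor, produces no step beyond the scatter. No available evidence accounts for this flat result. As far as these compounds go, it remains open whether an amine, a carboxylic acid or a longer chain at this carbon would leave the scatter, and whether changes elsewhere on the shared core would do so.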